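Chain Extension and Cytotoxicity Across Two Cores

The compounds below may be only part of what the source reports. "The series", "measured", "known", "first", "only" and "open" are said of these compounds alone.

Compound 1 `CC(=O)Nc1ccc(-c2nc3cc(C(F)(F)F)ccc3n2C)cc1` and compound 3 `CCC(=O)Nc1ccc(-c2nc3cc(C(F)(F)F)ccc3n2C)cc1` share one core, while compound 2 `CC(=O)Nc1ccc(-c2nc3ccccc3[nH]2)cc1` and compound 4 `CCC(=O)Nc1ccc(-c2nc3ccccc3[nH]2)cc1` share another. The difference between the two cores is not broken down here. In an ADME assay on Vero cells (Chlorocebus sabaeus) for cytotoxicity (on this read-out higher numbers stand for lower toxicity in this test and lower numbers for higher toxicity in this test), compound 1 gives only a limit, > 100000 nM. In this assay compound 3 likewise reaches only a limit, > 100000 nM. Compound 1 and compound 3 differ by methyl in place of hydrogen on a saturated chain carbon bound to a carbonyl carbon; the step that the two limits leave unreadable from compound 1 to compound 3. In this assay compound 2 also gives only a limit, > 100000 nM. Compound 4, not yet measured, differs from compound 2 by methyl in place of hydrogen on a saturated chain carbon bound to a carbonyl carbon, the same change that was made from compound 1 to compound 3, at a place described in the same words. All three measured values sit at the limit of > 100000 nM in this assay, at which 3 of the 3 values shown sit. Compound 4 is therefore expected to sit there as well, with an expected step of a number no higher from compound 2 to compound 4 (the limit leaves the size open), since the same change between compound 1 and compound 3 left both at the limit of > 100000 nM in this assay, at which 3 of the 3 values shown sit. For compound 4 the estimate in this assay is 100000 nM.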

Compound 4, half-maximal cytotoxic concentration: > 100000 nM
Compound 4: a limit, no number; the forecaster's own chance of this, stated with the estimate: 90%; the middle value lies on the limit itself.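

Compound 2 and compound 4 each give only a limit in this assay, so no step can be read between them: the limit of > 100000 nM in this assay, at which 4 of the 4 values shown sit.

The compounds shown leave open where any of the four truly lies past that limit, and so whether methyl in place of hydrogen on a saturated chain carbon bound to a carbonyl carbon changes the read-out on either core.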